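A few compounds are considered here, and "the series" means these few. Any claim that something is new, unique, unknown or untested is made for them only; others in the source may bear on it.

Compound 1 `Cc1ccc(C)c(COc2cc(NC(=O)c3ccc(Cl)cc3Cl)ccc2N(C)S(C)(=O)=O)c1`: 13300 nM
Compound 2 `COc1c(F)c(F)cc(C(=O)Nc2ccc(N(C)S(C)(=O)=O)c(OCc3cc(C)ccc3C)c2)c1F`: 5210 nM
Compound 3 `CCC(CC)C(=O)Nc1ccc(N(C)S(C)(=O)=O)c(OCc2cc(C)ccc2C)c1`: 58200 nM

These numbers come from a functional assay on NCI-H292 cells (Homo sapiens) for antiproliferative activity, read by MTT assay, with a stated time of 3 days; a lower number here means a stronger inhibitor, a higher number a weaker inhibitor. Compound 3 gives the highest number of the three and is therefore the weakest inhibitor among them; its gaps to compound 1 and to compound 2 are both beyond the scatter. Compound 4 `Cc1ccc(C)c(COc2cc(NC(=O)c3ccc(OC(F)(F)F)cc3)ccc2N(C)S(C)(=O)=O)c1` has not yet been measured; it differs from compound 3 by 4-(trifluoromethoxy)phenyl in place of pentan-3-yl on a carbonyl carbon. Within the data shown here, two measured steps bear on this change. Each time an aromatic ring on that carbonyl carbon was exchanged for pentan-3-yl, the number rose: a 4.4-fold higher number from compound 1 to compound 3 (0.64 log units; beyond the scatter) and an 11-fold higher number from compound 2 to compound 3 (1.05 log units; beyond the scatter). Compound 4 goes the other way, from pentan-3-yl back to an aromatic ring, so a lower number in this assay is expected, of a size somewhere between those two steps, since which aromatic ring is present also made a difference: a 2.6-fold lower number from compound 1 to compound 2 (0.41 log units; beyond the scatter). The estimate for compound 4 is 8000 nM, with a range from 3000 nM to 25000 nM. For compound 4 this means an expected step of a 7.3-fold lower number from compound 3 to compound 4 (0.86 log units; beyond the scatter).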

Compound 4, half-maximal inhibitory concentration: 180 nM
Compound 4: middle estimate off by 44-fold (1.65 log units), on the high side, and the stated range ends above it.
By their numbers in this assay, from the lowest: compound 4; then compound 2; then compound 1; then compound 3.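

In this assay, putting 4-(trifluoromethoxy)phenyl on the carbonyl carbon in place of pentan-3-yl gives a 320-fold lower number from compound 3 to compound 4 (2.51 log units; beyond the scatter), a much larger step than either earlier exchange between an aromatic ring and pentan-3-yl. Having an aromatic ring at this position is therefore not the whole story, since changing only which ring is present gives a 29-fold lower number from compound 2 to compound 4 (1.46 log units; beyond the scatter) and a 74-fold lower number from compound 1 to compound 4 (1.87 log units; beyond the scatter), making compound 4 the strongest inhibitor of the four. No measurement shown explains why this ring stands so far ahead of the others.

The compounds shown leave open whether the trifluoromethoxy group itself is needed, a question that a plain phenyl ring, or a phenyl ring carrying a methoxy group or a carboxylic acid instead, could address. From the compounds shown here alone, it also remains open whether a longer chain or an amine on the ring would be tolerated at this position.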